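A few compounds are considered here, and "the series" means these few. Any claim that something is new, unique, unknown or untested is made for them only; others in the source may bear on it.

Measured compounds:
compound 1 `C#CCNCc1cn(-c2cc(NC(=S)NCC)ncn2)cn1` — 5240 nM
compound 2 `C#CCN(C)Cc1cn(-c2cc(NC(=S)NCC)ncn2)cn1` — 1430 nM

In an assay on isolated protein for inhibition of Amine oxidase [flavin-containing] B (Homo sapiens), read by fluorescence and Amplex Red, with a stated time of 15 min (a higher number here means a weaker inhibitor, a lower number a stronger inhibitor), compound 2 gives 1430 nM, the lowest of the two numbers. Among the measured compounds shown here, its nearest neighbour is compound 1, which in this assay gives 5240 nM; the only measured step, a 3.7-fold lower number from compound 1 to compound 2 (0.56 log units; beyond the scatter), is the methyl put on the amine nitrogen.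

Compound 3 `C#CCN(CC)Cc1cn(-c2cc(NC(=S)NCC)ncn2)cn1` differs from compound 2 by methyl in place of hydrogen on a saturated chain carbon bound to an amine nitrogen. For the measured compounds named here, the one measured step bears on it only loosely: a 3.7-fold lower number from compound 1 to compound 2 (0.56 log units; beyond the scatter) shows that filling the amine nitrogen helped, but nothing measured says how lengthening that group further will read. The chain is extended by one carbon while the donor and acceptor counts stay unchanged. Going by the values given here, a step of a size comparable to the scatter, more likely a slightly higher number than a lower one, is therefore expected, since no measured step supports a further gain.

Compound 3 is estimated at 2500 nM in this assay, with a range of 900 nM to 7000 nM, an expected step of a 1.7-fold higher number from compound 2 to compound 3 (0.24 log units; within the scatter).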

Compound 3, half-maximal inhibitory concentration: > 50000 nM
Compound 3: only a limit was reported; the forecaster's own chance of this, stated with the estimate: 5%; middle value at least 20-fold (1.30 log units) away from the limit.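

In this assay, compound 3 is reported only as a limit of the assay, not as a number: the limit of > 50000 nM in this assay, at which 1 of the 3 values shown sits. The amine nitrogen proved far less forgiving than the first step suggested: methyl in place of hydrogen gave a 3.7-fold lower number from compound 1 to compound 2 (0.56 log units; beyond the scatter), whereas the single further carbon that turns methyl into ethyl gives an at least 34-fold higher number from compound 2 to compound 3 (1.54 log units; beyond the scatter). Even measured against the hydrogen on that nitrogen, ethyl gives an at least 9.5-fold higher number from compound 1 to compound 3 (0.97 log units; beyond the scatter), so the number does not move in one direction as this group grows: among the three compounds, methyl gives the lowest number, with both hydrogen and ethyl higher.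

From the compounds shown here alone, how far beyond the limit compound 3 truly lies remains unknown, so these two steps set only a minimum size for the change. Also open, going by these compounds, is how other groups on the same amine nitrogen would read, such as cyclopropyl, isopropyl or 2-hydroxyethyl, and whether an ethyl would give the same sharp rise if the propargyl group or the ethyl thiourea on the shared core were replaced.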